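From azetidin-1-yl to dimethylamino on the amide

The compounds below may be only part of what the source reports. "The series", "measured", "known", "first", "only" and "open" are said of these compounds alone.

- compound 1 `COc1cc(Cl)c(-c2nc(SCC(=O)NC3CC3)nc3[nH]cc(C#N)c23)cc1O`: 236 nM
- compound 2 `COc1cc(Cl)c(-c2nc(SCC(=O)NC(C)(C)C)nc3[nH]cc(C#N)c23)cc1O`: 152 nM
- compound 3 `COc1cc(Cl)c(-c2nc(SCC(=O)N3CCC3)nc3[nH]cc(C#N)c23)cc1O`: 28 nM

In a functional assay on MDA-MB-468 cells (Homo sapiens) for antiproliferative activity, read by sulforhodamine B assay, with a stated time of 4 days (on this read-out higher numbers stand for weaker inhibition of growth and lower numbers for stronger inhibition of growth), compound 3 gives 28 nM, the lowest of the three numbers, which makes it the strongest growth inhibitor so far. Compound 4 `COc1cc(Cl)c(-c2nc(SCC(=O)N(C)C)nc3[nH]cc(C#N)c23)cc1O` keeps the shared core and has dimethylamino in place of azetidin-1-yl on a carbonyl carbon.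

Two measured steps change the group at this same place: an 8.4-fold lower number from compound 1 to compound 3 (0.93 log units; beyond the scatter) and a 5.4-fold lower number from compound 2 to compound 3 (0.73 log units; beyond the scatter). Both are modest but beyond the scatter. A third, a 1.6-fold lower number from compound 1 to compound 2 (0.19 log units; within the scatter), stays within it. Compound 1 at 236 nM and compound 2 at 152 nM both keep the amide hydrogen, while compound 3 and compound 4 have none. Among the measured compounds shown here, no measured compound yet lacks both that hydrogen and a ring here, so the effect of opening the ring is unknown. A small rise in the number is therefore expected in this assay, probably not beyond the scatter. The estimated step is a 1.6-fold higher number from compound 3 to compound 4 (0.21 log units; within the scatter). The expected value for compound 4 is 45 nM, with an estimated range of 18 nM to 115 nM.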

Compound 4, concentration for 50% growth inhibition: 23 nM
Compound 4: the middle estimate sits 2.0-fold (0.29 log units) above what was measured, within the range that was stated.
By their numbers in this assay, from the lowest: compounds 4 and 3 (each within the scatter of the next); then compounds 2 and 1 (each within the scatter of the next).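

In this assay, opening the azetidin-1-yl ring to dimethylamino on this carbonyl carbon leaves the number within the scatter (a 1.2-fold lower number from compound 3 to compound 4 (0.09 log units; within the scatter)), so among the compounds shown, the four-membered ring is not required for a low number. Dimethylamino also stands clear of both groups that keep the amide hydrogen (a 6.6-fold lower number from compound 2 to compound 4 (0.82 log units; beyond the scatter); a 10-fold lower number from compound 1 to compound 4 (1.01 log units; beyond the scatter)), so both compounds without that hydrogen now give lower numbers than both compounds with it. Nothing measured here explains this link between the amide hydrogen and the numbers.

Methylamino is the sharpest open case, since it keeps the amide hydrogen on a smaller group than cyclopropylamino or (tert-butyl)amino. Also open, as far as these compounds go, is how far this position tolerates larger groups without the hydrogen, such as diethylamino, pyrrolidin-1-yl or morpholin-4-yl.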